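From phenyl to isopropyl in a series at its limit

A few compounds are considered here, and "the series" means these few. Any claim that something is new, unique, unknown or untested is made for them only; others in the source may bear on it.

Of the compounds shown here, three sharing one core have been tested in an ADME assay on HCT-116 cells (Homo sapiens) for cytotoxicity, read by CellTiter-Glo, with a stated time of 72 h (a lower number here means a stronger inhibitor, a higher number a weaker inhibitor), and none of them returned a number. Compound 1 (`CC1CCN(C2CCN(S(=O)(=O)c3ccc(Br)cc3OC(F)(F)F)CC2)CC1`) gives > 5000 nM as a limit of the assay. Compound 2 (`CC1CCN(C2CCN(S(=O)(=O)c3ccc(-c4ccccc4)cc3)CC2)CC1`) gives > 5000 nM which is likewise a limit. Compound 3 (`CC1CCN(C2CCN(S(=O)(=O)c3cccc(Br)c3)CC2)CC1`) gives > 5000 nM and this too is a limit. Compound 2 therefore stands with no value of its own, alongside two further limits, and the whole picture is the limit of > 5000 nM in this assay, at which 3 of the 3 values shown sit, for now.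

Compound 4 (`CC1CCN(C2CCN(S(=O)(=O)c3ccc(C(C)C)cc3)CC2)CC1`) carries isopropyl in place of phenyl on an aromatic carbon, para to a large group (isopropyl in place of phenyl on an aromatic carbon). Among the measured compounds shown here, no measured pair of compounds shows what such a change does. The expected size of the step that the limit leaves unreadable from compound 2 to compound 4 is none beyond the usual scatter, in either direction. That expectation rests on compound 2 and its limit > 5000 nM alone. Compound 4 is estimated at 7000 nM with an expected range from 3000 nM to 15000 nM in this assay once it is tested.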

Compound 4, half-maximal inhibitory concentration: > 5000 nM
Compound 4 was reported as a limit; the forecaster's own chance of this, stated with the estimate: 85%; the middle value lies beyond the limit too.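

The step from compound 2 to compound 4, phenyl to isopropyl, cannot be read, since each compound is reported only as a limit: the limit of > 5000 nM in this assay, at which 4 of the 4 values shown sit.

The compounds shown leave open how far past that limit each one lies, and whether any compound on the shared core would return a number in this assay.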